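Swapping the oxane for an aminopiperidine: an expectation

This account rests on a few compounds, and the source may have more. Where it says the series, first, only, none or still open, it means among the compounds named here.

Of the compounds shown here, three sharing one core have been tested in a physicochemical assay for solubility, at pH 2; on this read-out lower numbers stand for lower solubility and higher numbers for higher solubility. Compound 2 `Nc1nc(NC2CCNC2)c2sc(-c3ccc(C(F)(F)F)cc3)cc2n1` gives 155 ug/mL. Compound 3 `Nc1nc(NC2CCOCC2)c2sc(-c3ccc(C(F)(F)F)cc3)cc2n1` reaches only the lower limit of the assay, < 5 ug/mL. Compound 1 `CNc1nc(N2CCC(N)CC2)c2sc(-c3ccc(C(F)(F)F)cc3)cc2n1` sits at the upper limit of the assay, > 200 ug/mL. Within the data shown here, the single measured step between neighbours is an at least 31-fold lower number from compound 2 to compound 3 (1.49 log units; beyond the scatter). Compound 3 thus stands beyond the scatter below compound 2, and its number is a limit rather than a measured figure (the limit of < 5 ug/mL in this assay, at which 1 of the 3 values shown sits).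

Compound 4 `Nc1nc(N2CCC(N)CC2)c2sc(-c3ccc(C(F)(F)F)cc3)cc2n1` differs from compound 3 in one place: 4-aminopiperidin-1-yl in place of (oxan-4-yl)amino on an aromatic carbon. Among the measured compounds shown here, no measured step covers exactly this exchange. The step from compound 2 to compound 3 bears on it in part, as it too sets an oxan-4-yl group against a ring bearing a further nitrogen, and it was large. Compound 1 carries the same 4-aminopiperidin-1-yl group as compound 4 and reaches the upper limit (the limit of > 200 ug/mL in this assay, at which 1 of the 3 values shown sits). A large rise in this assay is therefore expected for compound 4, an at least 40-fold higher number from compound 3 to compound 4 (1.60 log units; beyond the scatter). Compound 4 is estimated at 200 ug/mL, within a range of 80 ug/mL to 400 ug/mL, with a real chance that the assay again reports only its upper limit.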

Compound 4, solubility: 134 ug/mL
Beside the measured number, compound 4's estimate is 1.5-fold (0.17 log units) above it, and the stated range covers the measured number.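

Putting 4-aminopiperidin-1-yl in place of (oxan-4-yl)amino on this aromatic carbon of the shared core gives an at least 26-fold higher number from compound 3 to compound 4 (1.42 log units; beyond the scatter) in this assay, so the exchange now has a measured step of its own, though its size is only a floor, as compound 3 stands at a limit: the limit of < 5 ug/mL in this assay, at which 1 of the 4 values shown sits. The exact ring matters little among the two amine-bearing groups shown, since (pyrrolidin-3-yl)amino and 4-aminopiperidin-1-yl cannot be told apart, with a 1.2-fold lower number from compound 2 to compound 4 (0.06 log units; within the scatter), and the oxane of compound 3 is the only group here that stands apart from them. The methyl on the nitrogen on the aromatic ring cannot be judged, with an at least 1.4-fold lower number from compound 1 to compound 4 (0.17 log units; that floor lies within the scatter), and no order between these two compounds can be stated, as compound 1 stands at a limit: the limit of > 200 ug/mL in this assay, at which 1 of the 4 values shown sits.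

From the compounds shown here alone, whether a 4-hydroxypiperidine, which keeps the ring of compound 4 but swaps its amine for a hydroxyl, or a piperazine or a morpholine on this carbon would fall with compound 3 or with compound 4 stays open. Going by these compounds, how far the gap holds at any pH other than the one used in this assay also stays open.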